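Dropping the Amino Group from a Chloro-Substituted Fused Core

This account rests on a few compounds, and the source may have more. Where it says the series, first, only, none or still open, it means among the compounds named here.

Measured compounds:
- compound 1 `Nc1nc(Cl)c2ncn(Cc3ccccc3CCl)c2n1`: 15100 nM
- compound 2 `ClCc1ccc(Cn2cnc3c(Cl)nc(Cl)nc32)cc1`: 2690 nM

In a functional assay on PC-3 cells (Homo sapiens) for cytotoxicity, read by sulforhodamine B assay, with a stated time of 48 h (a lower number here means a stronger inhibitor of growth, a higher number a weaker inhibitor of growth), compound 1 gives 15100 nM, the higher of the two numbers and therefore the weaker growth inhibitor of the pair. Compound 2 gives 2690 nM in this assay, but it differs from compound 1 in more than one place, so no single change can be read from the gap.

Compound 3 `ClCc1ccccc1Cn1cnc2c(Cl)ncnc21` keeps everything of compound 1 except at one spot: hydrogen in place of amino on an aromatic carbon. The change removes one hydrogen-bond donor and one acceptor on an aromatic carbon of a six-membered aromatic ring with two nitrogen atoms, between two ring nitrogen atoms.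

Among the measured compounds shown here, no measured pair shows this exact change, so the step from compound 1 to compound 3 is uncertain. Compound 3 is expected to land near compound 1, with at most a modest shift in this assay, a 1.7-fold lower number from compound 1 to compound 3 (0.22 log units; within the scatter). The estimate for compound 3 is 9000 nM, within 3000 nM to 27000 nM.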

Compound 3, concentration for 50% growth inhibition: 3020 nM
Estimate against measurement, compound 3: 3.0-fold (0.47 log units) above; measured number inside the range.
By their numbers in this assay, from the lowest: compounds 2 and 3 (each within the scatter of the next); then compound 1.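

In this assay, replacing the amino group with hydrogen on this aromatic carbon, between two ring nitrogen atoms, gives a 5.0-fold lower number from compound 1 to compound 3 (0.70 log units; beyond the scatter) and so makes the compound a stronger inhibitor of growth. Among the compounds shown here, this is the first comparison here in which only one place changes, and it shows that the amino group at this position is not needed for growth inhibition in these cells. Nothing available here explains why removing the amino group has this effect.

As far as these compounds go, it remains open whether a small group such as methyl or methoxy on the same carbon would give a number closer to that of the amino compound or the hydrogen compound. From the compounds shown here alone, whether the same swap gives a step of similar size when other parts of the molecule differ also remains open.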